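The source may hold more compounds than are shown below. What is called first, only, known or untested is meant among the compounds shown, and "the series" means these compounds.

Compound 1 `COC(=O)/C=C/c1cccc(N(Cc2ccc(/C=C/c3cccc(F)c3)cc2)C(=O)C2CCCCC2)c1`: in an assay on isolated protein with Bile acid receptor (Homo sapiens) as the target (a higher number here means that more compound is needed for the effect, a lower number that less compound is needed), compound 1 gives 86 nM.
Compound 2 `COC(=O)/C=C/c1cccc(N(Cc2ccc(-c3cccc(Cl)c3)cc2)C(=O)C2CCCCC2)c1`: in this assay compound 2 gives 94 nM.
Compound 3 `CCOC(=O)/C=C/c1ccc(CN(C(=O)C2CCCCC2)c2cccc(/C=C/C(=O)OC)c2)cc1`: in this assay compound 3 gives only a limit, > 1000 nM.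

Compound 3 therefore stands at the limit of > 1000 nM in this assay, at which 1 of the 3 values shown sits, with no number of its own. Compound 4 `COC(=O)/C=C/c1cccc(N(Cc2ccc(/C=C/c3c(Cl)cccc3Cl)cc2)C(=O)C2CCCCC2)c1` differs from it by 2,6-dichlorophenyl in place of ethoxycarbonyl on a double-bonded chain carbon bound to a double-bonded chain carbon. Within the data shown here, the steps that bear on this are an at least 11-fold higher number from compound 1 to compound 3 (1.06 log units; beyond the scatter) and an at least 10-fold higher number from compound 2 to compound 3 (1.02 log units; beyond the scatter), each a large loss on going toward the ethoxycarbonyl group. Compound 4 undoes that change and carries a substituted phenyl ring on the ethenyl chain, as compound 1 does, so a large drop in the number, beyond the scatter, is expected: an at least 8.3-fold lower number from compound 3 to compound 4 (0.92 log units; beyond the scatter). Compound 4 is estimated at 120 nM, within 40 nM to 400 nM.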

Compound 4, half-maximal effective concentration: 150 nM
The estimate for compound 4 lay 1.3-fold (0.10 log units) below the measured number, within the range that was stated.
By their numbers in this assay, from the lowest: compounds 1, 2 and 4 (each within the scatter of the next). At a limit, above all of these: compound 3.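

In this assay, a second substituted phenyl ring on the double-bonded chain carbon also clears the loss seen with ethoxycarbonyl, giving an at least 6.6-fold lower number from compound 3 to compound 4 (0.82 log units; beyond the scatter) at this position. That step starts from a limit for compound 3, not from a number: the limit of > 1000 nM in this assay, at which 1 of the 4 values shown sits. The 2,6-dichlorophenyl group serves as well as 3-fluorophenyl, with a 1.7-fold higher number from compound 1 to compound 4 (0.24 log units; within the scatter) and, on the aromatic carbon, 2-(2,6-dichlorophenyl)ethenyl matches 3-chlorophenyl, with a 1.6-fold higher number from compound 2 to compound 4 (0.20 log units; within the scatter). The compounds shown leave open whether a ring is needed at this place at all, or whether an amide or a carboxylic acid there would also keep the number low.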